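The source may hold more compounds than are shown below. What is called first, only, known or untested is meant among the compounds shown, and "the series" means these compounds.

Measured compounds:
compound 1 `COc1ccc(-c2cc(=O)c3c(OC)cc(OC)cc3n2Cc2ccccc2)cc1`: > 34400 nM
compound 2 `COc1ccc(-c2c(Cl)c(=O)c3c(OC)cc(OC)cc3n2S(=O)(=O)c2ccc(OC)cc2)cc1`: 90000 nM
compound 3 `COc1ccc(-c2c(Br)c(=O)c3c(OC)cc(OC)cc3n2S(=O)(=O)c2ccc(OC)cc2)cc1`: 49700 nM

In an ADME assay on BJ cells (Homo sapiens) for antiproliferative activity, with a stated time of 72 h (on this read-out lower numbers stand for an effect already at smaller amounts and higher numbers for an effect only at larger amounts of compound), compound 1 sits at a limit, (the limit of > 34400 nM in this assay, at which 1 of the 3 values shown sits), so it has no number of its own. Within the data shown here, compound 2 gives 90000 nM and compound 3 gives 49700 nM; the one measured step, a 1.8-fold lower number from compound 2 to compound 3 (0.26 log units; within the scatter), does not reach beyond the scatter. Compound 4 `COc1ccc(-c2cc(=O)c3c(OC)cc(OC)cc3n2S(=O)(=O)c2ccc(F)cc2)cc1` arises from compound 1 by (4-fluorophenyl)sulfonyl in place of benzyl on an aromatic nitrogen. Among the measured compounds shown here, no measured step covers this change; compounds 2 and 3 carry a related sulfonyl group and both lie in the same high region, while compound 1 offers only a limit. The estimate for compound 4 is therefore 60000 nM (range 30000 nM to 120000 nM), a step that the limit leaves unreadable from compound 1 to compound 4 expected to stay within the scatter.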

Compound 4, half-maximal effective concentration: > 65500 nM
Compound 4: only a limit was reported; the forecaster's own chance of this, stated with the estimate: 40%; at least 1.0-fold (0.03 log units) between middle value and limit.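

Compound 1 and compound 4 are each reported only as a limit, so the step between them cannot be read in this assay. Going by these compounds, whether (4-fluorophenyl)sulfonyl in place of benzyl on the aromatic nitrogen changes the antiproliferative effect stays open.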